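The compounds below may be only part of what the source reports. "The series", "measured", "known", "first", "only" and "open" are said of these compounds alone.

In a functional assay on MIA PaCa-2 cells (Homo sapiens) for inhibition, read by MTT assay, with a stated time of 3 days (on this read-out lower numbers stand for stronger inhibition and higher numbers for weaker inhibition), compound 1 (`CCN(CC)S(=O)(=O)c1ccc(S(=O)(=O)N2CCC[C@@H](C(=O)N3CCC(OC)CC3)C2)cc1`) gives only a limit, > 10000 nM. Compound 2 (`CCN(CC)S(=O)(=O)c1ccc(S(=O)(=O)N2CCC[C@@H](C(=O)N3CCOCC3)C2)cc1`) also gives only a limit, > 10000 nM. This means that compound 2 has no exact value to serve as a starting point. The next compound, compound 3 (`CCN(CC)S(=O)(=O)c1ccc(S(=O)(=O)N2CCC[C@@H](C(=O)N3CCC(F)(F)CC3)C2)cc1`), has 4,4-difluoropiperidin-1-yl in place of morpholin-4-yl on a carbonyl carbon. Within the data shown here, the only measured step at this carbonyl carbon is a step that the two limits leave unreadable from compound 1 to compound 2, so it offers no size to carry over. The evidence so far amounts to the limit of > 10000 nM in this assay, at which 2 of the 2 values shown sit. Neither measured compound shows a readable inhibition value, so no step beyond the usual scatter, in either direction, is expected in this assay. The expected change is a step that the limit leaves unreadable from compound 2 to compound 3. For compound 3 the estimated value is 12000 nM, with an expected range of 4000 nM to 30000 nM, and the assay may well again report only a limit.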

Compound 3, half-maximal inhibitory concentration: > 10000 nM
Compound 3: no number, only a limit; the forecaster's own chance of this, stated with the estimate: 70%; the middle value does not contradict the limit.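

In this assay compound 3 gives only a limit, > 10000 nM. The steps among compound 1, compound 2 and compound 3 therefore cannot be read. The compounds shown leave open whether any group on this carbonyl carbon would give a readable inhibition value.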